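The compounds below may be only part of what the source reports. "The series", "measured", "known", "first", "only" and "open" are said of these compounds alone.

In a functional assay on HCT-116 cells (Homo sapiens) for cytotoxicity, read by sulforhodamine B assay, with a stated time of 72 h (a higher number here means a weaker inhibitor, a lower number a stronger inhibitor), compound 1 `Cc1c(O)c(C)c(C(C)C)c(O[C@@H]2O[C@H](CO)[C@@H](O)[C@H](O)[C@H]2O)c1O` gives > 40000 nM, which is a limit of the assay and not a number. Compound 2 `COc1c(C)c(O)c(C)c(C(C)C)c1C(=O)SC` gives > 40000 nM, again only a limit. Among the compounds with values here, compound 3 `COC(=O)c1c(O)c(C)c(O)c(C)c1C(C)C` gives 7300 nM, the only true number among the three, and this makes it the sole numerical reference point. Compound 4 `Cc1c(O)cc(C(C)C)c(C)c1O` has hydrogen in place of methoxycarbonyl on an aromatic carbon. Within the data shown here, no measured pair shows what this change does, and the expectation starts from the value of compound 3 at 7300 nM. A modest step towards weaker inhibition is expected, estimated as a 1.6-fold higher number from compound 3 to compound 4 (0.22 log units; within the scatter), with wide uncertainty. For compound 4 the estimated value is 12000 nM, with an expected range from 3000 nM to 40000 nM.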

Compound 4, half-maximal inhibitory concentration: > 40000 nM
Compound 4 ended at the assay's limit; the forecaster's own chance of this, stated with the estimate: 25%; at least 3.3-fold (0.52 log units) between middle value and limit.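

Within the data shown here, replacing methoxycarbonyl with hydrogen on this aromatic carbon, ortho to a hydroxy group and ortho to an isopropyl group, gives the first measured step at this position: in this assay there is an at least 5.4-fold higher number from compound 3 to compound 4 (0.73 log units; beyond the scatter). Among these two compounds, then, a measurable value is seen only with methoxycarbonyl in place. Only a minimum for this step can be read, because compound 4 gives a limit and not a number: the limit of > 40000 nM in this assay, at which 3 of the 4 values shown sit.

On these data alone, it remains open whether a carboxylic acid, a primary amide or an ethoxycarbonyl group on this carbon would match compound 3 at 7300 nM.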